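A few compounds are considered here, and "the series" means these few. Any claim that something is new, unique, unknown or untested is made for them only; others in the source may bear on it.

Compound 1, `Cc1ccccc1-c1cnc(NC(=O)c2ccc(F)cc2)n1C`, was tested in a toxicity assay on THP-1 cells (Homo sapiens) for inhibition; a higher number here means that more compound is tolerated, a lower number that less compound is tolerated. In this assay compound 1 gives > 50000 nM, which is a limit of the assay rather than a measured number. For the measured compounds named here, the only other compound with a result here is compound 2, `COc1ccc(-c2cnc(NC(C)=O)n2C)cc1`. In this assay compound 2 gives > 100000 nM, again a limit and not a number. Going by the values given here, compound 1 therefore stands on a limit, and the one further value in the set is also a limit: one value sits at the limit of > 100000 nM in this assay, at which 1 of the 2 values shown sits, and one at the limit of > 50000 nM in this assay, at which 1 of the 2 values shown sits. Among the compounds with values here, neither result reports a half-maximal cytotoxic concentration as a number, so no step between measured compounds can be given.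

Compound 3, `Cn1c(-c2ccc(Br)cc2)cnc1NC(=O)c1ccc(F)cc1`, has not yet been tested. It differs from compound 1 in one place: 4-bromophenyl in place of 2-methylphenyl on an aromatic carbon. Since compound 1 tolerates the full tested range, no step beyond the usual scatter is expected in this assay; the step from compound 1 to compound 3 is expected to be a number no higher from compound 1 to compound 3 (the limit leaves the size open). For compound 3 the half-maximal cytotoxic concentration is expected to be about 50000 nM, in a range from 20000 nM to 100000 nM, most probably reported again only as a limit.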

Compound 3, half-maximal cytotoxic concentration: 46000 nM
The estimate for compound 3 lay 1.1-fold (0.04 log units) above the measured number; measured number inside the range.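

At this aromatic carbon of the shared core, 4-bromophenyl in place of 2-methylphenyl gives an at least 1.0-fold lower number from compound 1 to compound 3 (0.03 log units; that floor lies within the scatter) in this assay, so no change beyond the scatter can be claimed for this exchange. Compound 3 is the first compound shown with a half-maximal cytotoxic concentration that is a number rather than a limit, 46000 nM, so this position can carry a group with which the end point is reached within the tested range. Compound 1 stands only on a limit, which leaves the true size of the step unknown: the limit of > 50000 nM in this assay, at which 1 of the 3 values shown sits.

The compounds shown leave open whether the result for compound 3 goes with the bromine or with the place of the substituent on the phenyl ring, as the two groups differ in both the atom and its place. As far as these compounds go, how a 4-methylphenyl or a 2-bromophenyl group would behave at this carbon in this assay also stays open, as does the effect of an amine or a carboxylic acid on that ring.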